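The source may report more compounds than this note shows. Statements on the series, on what has been measured and on what is new or still open speak of the compounds shown alone.

Three related compounds share one core, and in a functional assay on Huh-7 cells (Homo sapiens) for cytotoxicity, read by resazurin assay, with a stated time of 48 h (a lower number here means a stronger inhibitor, a higher number a weaker inhibitor), their numbers are close together. Compound 1 `CCN/C(SC)=C(/C#N)C(=O)Nc1ccc(OCC)cc1` gives 16400 nM. Compound 2 `C=CCN/C(SC)=C(/C#N)C(=O)Nc1ccc(OCC)cc1`, which carries a vinyl in place of the methyl on the chain bound to the amine nitrogen, gives 8850 nM, and the step of a 1.9-fold lower number from compound 1 to compound 2 (0.27 log units; within the scatter) stays inside the usual scatter. Compound 3 `CCOc1ccc(NC(=O)/C(C#N)=C(\Nc2ccccc2)SC)cc1`, with a phenyl on that amine nitrogen, gives 25300 nM, the highest of the three numbers; its step from compound 1 is a 1.5-fold higher number from compound 1 to compound 3 (0.19 log units; within the scatter), while the step of a 2.9-fold higher number from compound 2 to compound 3 (0.46 log units; beyond the scatter) is the only one of the three that reaches beyond the scatter.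

Compound 4 `CCOc1ccc(NC(=O)/C(C#N)=C(\NC)SC)cc1` takes the change (methyl in place of phenyl on an amine nitrogen). The two steps that bear on it are those that put a phenyl onto the same nitrogen: from an ethyl, a step within the scatter, and from an allyl, a modest rise. Taking the phenyl away again and leaving a methyl is therefore expected to undo a small part of that rise, so that compound 4 is expected to land near compound 1, with the step from compound 3 to compound 4 estimated as a 1.7-fold lower number from compound 3 to compound 4 (0.23 log units; within the scatter). In this assay compound 4 is estimated at 15000 nM, within a range from 6000 nM to 38000 nM.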

Compound 4, half-maximal inhibitory concentration: 5780 nM
Beside the measured number, compound 4's estimate is 2.6-fold (0.41 log units) above it; measured number below the stated range.
By their numbers in this assay, from the lowest: compounds 4, 2, 1 and 3 (each within the scatter of the next, the first and the last beyond it).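

For the compounds shown here, at the amine nitrogen, swapping phenyl for methyl gives the widest step in this small set (a 4.4-fold lower number from compound 3 to compound 4 (0.64 log units; beyond the scatter)) in this assay, so the earlier steps, which started from ethyl and allyl, did not show how much the choice of group here can move the number. Methyl also stands apart from ethyl (a 2.8-fold lower number from compound 1 to compound 4 (0.45 log units; beyond the scatter)) but not from allyl (a 1.5-fold lower number from compound 2 to compound 4 (0.19 log units; within the scatter)), so the idea that a shorter chain goes with a lower number holds for compound 4 against compound 1, while compound 2, with its longer allyl chain, goes against it. The data shown offer no explanation for why these groups rank as they do.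

The compounds shown leave open what happens with a bare amine hydrogen, a cyclopropyl or a benzyl on this nitrogen, and whether a chain ending in a hydroxyl or an amine would fit the same picture. From the compounds shown here alone, every comparison here also rests on a single cell line and changes only this one nitrogen, so it remains open whether the same order would hold in other cells or with a different group in place of the ethoxy.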